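The compounds below may be only part of what the source reports. "The series", "measured", "known", "first", "only" and "open" are said of these compounds alone.

Compound 1 `O=C(O)c1ccccc1-c1ccc(CCc2ncc(CC3CCC3)[nH]2)cc1` gives 588 nM in an in vitro functional assay on cells for agonist activity at Bombesin receptor subtype-3 (Homo sapiens), read by luminescence and calcium flux; a lower number here means that less compound is needed, a higher number that more compound is needed for the effect. Compound 2 `Cc1ccccc1Cc1cnc(CCc2ccc(-c3ccccc3C(=O)O)cc2)[nH]1` gives 127 nM. Compound 3 `O=C(O)c1ccccc1-c1ccc(CCc2ncc(CCC3CCCCC3)[nH]2)cc1` gives 642 nM.

Compound 3 has the highest number of the three, though it sits within the scatter of compound 1 a 1.1-fold higher number from compound 1 to compound 3 (0.04 log units; within the scatter) and is clearly separated only from compound 2 a 5.1-fold higher number from compound 2 to compound 3 (0.70 log units; beyond the scatter). Compound 4 `Cc1ccc(Cc2cnc(CCc3ccc(-c4ccccc4C(=O)O)cc3)[nH]2)cc1` differs from compound 3 in one place: 4-methylphenyl in place of cyclohexylmethyl on a saturated chain carbon bound to an aromatic carbon. The informative steps are the two that swap a saturated ring for an aromatic one or back: a 4.6-fold lower number from compound 1 to compound 2 (0.67 log units; beyond the scatter) and a 5.1-fold higher number from compound 2 to compound 3 (0.70 log units; beyond the scatter). Both point the same way, so the aromatic ring entering here is expected to bring a modest decrease in this assay, roughly reversing the earlier step of a 3.6-fold lower number from compound 3 to compound 4 (0.55 log units; beyond the scatter). Compound 4 is therefore estimated at 180 nM, within a range of 70 nM to 450 nM.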

Compound 4, half-maximal effective concentration: 2660 nM
Compound 4: the middle estimate sits 15-fold (1.17 log units) below what was measured, and the stated range ends below it.
By their numbers in this assay, from the lowest: compound 2; then compounds 1 and 3 (each within the scatter of the next); then compound 4.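

Placing an aromatic ring at this position does not by itself lower the number: 4-methylphenyl gives a higher number than cyclohexylmethyl (a 4.1-fold higher number from compound 3 to compound 4 (0.62 log units; beyond the scatter)) and than cyclobutyl (a 4.5-fold higher number from compound 1 to compound 4 (0.66 log units; beyond the scatter)). The placement of the methyl on the ring has the largest effect seen in this set, as 4-methylphenyl in place of 2-methylphenyl shows (a 21-fold higher number from compound 2 to compound 4 (1.32 log units; beyond the scatter)). Nothing available explains why these two groups differ so much.

Still open, from the compounds shown here alone, is how an unsubstituted phenyl or a 3-methylphenyl group would read here. Going by these compounds, it is also open whether a 2-chlorophenyl or 2-methoxyphenyl group would match the 2-methylphenyl result.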